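The compounds below may be only part of what the source reports. "The series", "measured", "known", "first", "only" and "open" are said of these compounds alone.

Measured compounds:
compound 1, `Cn1ncc(Cl)c1-c1cc(C(=O)N[C@@H]2CN[C@H](CCO)C[C@H]2c2ccc(F)c(F)c2)oc1Cl`, 0.98 nM in an assay for inhibition of RAC-alpha serine/threonine-protein kinase (Homo sapiens), read by HTRF, with a stated time of 1 h; on this read-out higher numbers stand for weaker inhibition and lower numbers for stronger inhibition
compound 2, `COCC[C@@H]1C[C@@H](c2ccc(Cl)c(Cl)c2)[C@H](NC(=O)c2cc(-c3c(Cl)cnn3C)c(Cl)o2)CN1`, 7.01 nM
compound 3, `Cn1ncc(Cl)c1-c1cc(C(=O)N[C@@H]2CN[C@H](CCO)C[C@H]2c2ccc(Cl)c(Cl)c2)oc1Cl`, 2.74 nM

Compound 1 gives the lowest of the three numbers; the nearest is compound 3, a 2.8-fold higher number from compound 1 to compound 3 (0.45 log units; beyond the scatter), the furthest compound 2. The unmeasured compound 4, `Cn1ncc(Cl)c1-c1cc(C(=O)N[C@@H]2CN[C@H](CC(O)CO)C[C@H]2c2ccc(F)c(F)c2)oc1Cl`, differs from compound 1 by hydroxymethyl in place of hydrogen on a saturated chain carbon bound to an oxygen on a saturated carbon and a saturated chain carbon. Within the data shown here, of the measured steps, only the one within the same side chain is of use, a 2.6-fold lower number from compound 2 to compound 3 (0.41 log units; beyond the scatter), and it concerns the oxygen, not a further hydroxymethyl; the aryl step does not bear. On these data alone, a 2,3-dihydroxypropyl chain is untested here. The expected step of a 1.5-fold higher number from compound 1 to compound 4 (0.18 log units; within the scatter) is therefore small, a slightly higher number at most, possibly none beyond the scatter. Compound 4 is estimated at 1.5 nM, within 0.6 nM to 4 nM.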

Compound 4, half-maximal inhibitory concentration: 3.31 nM
Estimate against measurement, compound 4: 2.2-fold (0.34 log units) below; the range from low to high includes it.
By their numbers in this assay, from the lowest: compound 1; then compounds 3 and 4 (each within the scatter of the next); then compound 2.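

In this assay, among these compounds, changing 2-hydroxyethyl to 2,3-dihydroxypropyl on the 3,4-difluorophenyl compound gives a 3.4-fold higher number from compound 1 to compound 4 (0.53 log units; beyond the scatter), the first reading of an added hydroxymethyl on this chain. The earlier side-chain step concerned only a methyl on the oxygen, whereas this one shows that the chain can be extended at a modest cost. No measurement here accounts for the step.

On these data alone, it remains open whether an amine or a carboxylic acid in place of the added hydroxymethyl would give a lower or higher number. As far as these compounds go, the effect of the 2,3-dihydroxypropyl chain alongside 3,4-dichlorophenyl also remains open.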